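Cinnamoyl sulfonamides: methyl to bromo on the sulfonyl ring

The compounds below may be only part of what the source reports. "The series", "measured", "known", "first", "only" and "open" are said of these compounds alone.

Measured so far:
compound 1 `CN(C)c1ccc(/C=C/C(=O)NS(=O)(=O)c2ccc(Br)cc2)cc1`, 4.2 ug/mL
compound 2 `Cc1ccc(S(=O)(=O)NC(=O)/C=C/c2ccc([N+](=O)[O-])cc2)cc1`, 13.5 ug/mL

Among the compounds with values here, in a functional assay on B16-F10 cells (Mus musculus) for antiproliferative activity, read by ELISA and MTT assay, with a stated time of 48 h (a lower number here means a stronger inhibitor, a higher number a weaker inhibitor), compound 2 gives 13.5 ug/mL, the highest of the two numbers; compound 1 gives 4.2 ug/mL, a gap beyond the scatter, and no single step between the two is known. Compound 3 `O=C(/C=C/c1ccc([N+](=O)[O-])cc1)NS(=O)(=O)c1ccc(Br)cc1` carries bromo in place of methyl on an aromatic carbon. Within the data shown here, no measured pair shows this change, so the step of a 1.4-fold lower number from compound 2 to compound 3 (0.13 log units; within the scatter) is expected to be small, with no direction resolvable beyond the scatter. Compound 3 is estimated at 10 ug/mL, in a range from 4 ug/mL to 25 ug/mL.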

Compound 3, half-maximal inhibitory concentration: 13.9 ug/mL
Compound 3: middle estimate off by 1.4-fold (0.14 log units), on the low side, and the stated range covers the measured number.
By their numbers in this assay, from the lowest: compound 1; then compounds 2 and 3 (each within the scatter of the next).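

With nitro held constant in this assay, bromo in place of methyl on the sulfonyl ring gives no resolvable change (a 1.0-fold higher number from compound 2 to compound 3 (0.01 log units; within the scatter)), so this position does not separate 4-methylphenyl from 4-bromophenyl here. Within the data shown here, with 4-bromophenyl held constant, nitro in place of dimethylamino is a larger step (a 3.3-fold higher number from compound 1 to compound 3 (0.52 log units; beyond the scatter)), the first single-place step beyond the scatter. No measured evidence accounts for either step.

Still open, on these data alone, is whether bromo and methyl also match when dimethylamino replaces nitro. Also open, as far as these compounds go, is whether a carboxylic acid or a longer chain in place of bromo would shift the number at this position.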